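From compound 2 to compound 3 at the sulfonyl sulfur

A few compounds are considered here, and "the series" means these few. Any claim that something is new, unique, unknown or untested is made for them only; others in the source may bear on it.

Measured so far in an ADME assay on microsomes (Homo sapiens) for metabolic stability (on this read-out lower numbers stand for slow clearance and higher numbers for fast clearance), are two compounds:
- compound 1 `Cc1cc(C(F)(F)F)c2cccc(OCc3c(Cl)ccc(S(=O)(=O)N4CC[C@@H](N(C)C)C4)c3Cl)c2n1` with 167 mL/min/kg
- compound 2 `Cc1cc(C(F)(F)F)c2cccc(OCc3c(Cl)ccc(S(=O)(=O)N4C[C@@H](C)O[C@@H](C)C4)c3Cl)c2n1` with 317 mL/min/kg

In this assay compound 2 stands at 317 mL/min/kg and sits within the scatter of compound 1 at 167 mL/min/kg on this small set. Compound 3 `Cc1cc(C(F)(F)F)c2cccc(OCc3c(Cl)ccc(S(=O)(=O)N4CCC(C#N)CC4)c3Cl)c2n1` has not yet been measured. It carries 4-cyanopiperidin-1-yl in place of 2,6-dimethylmorpholin-4-yl on a sulfonyl sulfur, and the change reads 4-cyanopiperidin-1-yl in place of 2,6-dimethylmorpholin-4-yl on a sulfonyl sulfur in full. Within the data shown here, one measured step bears on it, at the same sulfonyl sulfur, namely a 1.9-fold higher number from compound 1 to compound 2 (0.28 log units; within the scatter) and this stays within the scatter. Among the measured compounds shown here, no measured compound carries the entering group, so no step beyond the scatter is expected. The expected size is a 1.4-fold lower number from compound 2 to compound 3 (0.14 log units; within the scatter) and it remains within the scatter. For compound 3 the estimated clearance is 230 mL/min/kg with an expected range from 100 mL/min/kg to 480 mL/min/kg in this assay.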

Compound 3, clearance: 433 mL/min/kg
For compound 3 the middle estimate is 1.9-fold (0.27 log units) below the measured one; measured number inside the range.
By their numbers in this assay, from the lowest: compounds 1, 2 and 3 (each within the scatter of the next, the first and the last beyond it).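

In this assay, 4-cyanopiperidin-1-yl in place of 2,6-dimethylmorpholin-4-yl on the sulfonyl sulfur gives a 1.4-fold higher number from compound 2 to compound 3 (0.14 log units; within the scatter) and so does not separate these two groups on this read-out, even though a nitrile enters and the ring oxygen and both defined stereocentres leave. Set against the 3-(dimethylamino)pyrrolidin-1-yl group of compound 1, the same position now yields its first step past the usual scatter, a 2.6-fold higher number from compound 1 to compound 3 (0.41 log units; beyond the scatter) and still a modest one. No measurement at hand accounts for either step.

Compound 1 alone carries the dimethylamino group, so the compounds shown cannot tell whether that group or its pyrrolidine ring goes with its lower number. Going by these compounds, how a plain piperidine, a piperazine or a piperidine bearing a carboxylic acid would read at this sulfur also stays open.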